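One Fluoro Added to Compound 1

A few compounds are considered here, and "the series" means these few. Any claim that something is new, unique, unknown or untested is made for them only; others in the source may bear on it.

Within the data shown here, in a functional assay on A549 cells (Homo sapiens) for cytotoxicity, read by MTT assay, with a stated time of 72 h (on this read-out higher numbers stand for weaker inhibition and lower numbers for stronger inhibition), compound 1 (`Cn1ccc2c(Oc3ccc(NC(=O)c4cc5cccnc5n(-c5ccc(Br)cc5)c4=O)cc3)ncnc21`) gives 52200 nM and holds the lower of the two numbers known so far. On the same measure, compound 2 (`Cn1ccc2c(Oc3ccc(NC(=O)c4cc5cccnc5n(-c5ccc(C(F)(F)F)cc5Cl)c4=O)cc3)ncnc21`) gives 364000 nM as the higher number. A lower number here means stronger inhibition, so compound 1 is the better of this pair.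

Compound 3 (`Cn1ccc2c(Oc3ccc(NC(=O)c4cc5cccnc5n(-c5ccc(Br)cc5)c4=O)cc3F)ncnc21`) has not yet been measured. It has one change from compound 1: fluoro in place of hydrogen on an aromatic carbon in words, fluoro in place of hydrogen on an aromatic carbon, ortho to a large group and meta to a large group.

Among the measured compounds shown here, only one measured step can serve as a guide. It is a 7.0-fold higher number from compound 1 to compound 2 (0.84 log units; beyond the scatter) and it comes from swapping a whole group on an aromatic nitrogen, with 2-chloro-4-(trifluoromethyl)phenyl in place of 4-bromophenyl. That swap is at a different place and is larger than the new change, so it gives only a rough gauge. In this assay a smaller step is expected, probably none beyond the scatter and with no firm direction.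

The estimate amounts to a 1.1-fold higher number from compound 1 to compound 3 (0.06 log units; within the scatter) as an expected step. Compound 3 is expected at 60000 nM with an estimated range of 22000 nM to 160000 nM in this measure.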

Compound 3, half-maximal inhibitory concentration: 42200 nM
For compound 3 the middle estimate is 1.4-fold (0.15 log units) above the measured one; the range from low to high includes it.
By their numbers in this assay, from the lowest: compounds 3 and 1 (each within the scatter of the next); then compound 2.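

Placing a fluoro on this aromatic carbon, ortho to a large group and meta to a large group, gives a 1.2-fold lower number from compound 1 to compound 3 (0.09 log units; within the scatter) in this assay and so stays within the usual scatter of repeated measurements. Among these compounds, the earlier pair showed only that the group on the aromatic nitrogen can matter, with a 7.0-fold higher number from compound 1 to compound 2 (0.84 log units; beyond the scatter) beyond the scatter, and it said nothing about this carbon on the other side of the molecule. Here the first look at this carbon shows that a single fluorine atom in place of hydrogen can be accepted in this cell assay without a step that can be told from the scatter, though no measurement at hand explains this result.

The compounds shown leave open whether a different group on this carbon, such as a methoxy group, an amine or a carboxylic acid, would also stay within the scatter or would produce a clear step. They also leave open whether fluoro here would give a similarly small step when the 2-chloro-4-(trifluoromethyl)phenyl group of compound 2 sits on the aromatic nitrogen.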